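Replacing the fused ring of compound 1 with pyrrolidine

The source may report more compounds than this note shows. Statements on the series, on what has been measured and on what is new or still open speak of the compounds shown alone.

Measured compounds and their values:
- Compound 1 `CN(c1ccc(Oc2ncnc3sccc23)cc1)c1nccc(N2CCc3ccccc3C2)n1` gives 6390 nM
- Compound 2 `CN(c1ccc(Oc2ncnc3ccsc23)cc1)c1nccc(N2CCc3ccccc3C2)n1` gives 16200 nM
- Compound 3 `c1cc(N2CCCCC2)nc(Nc2ccc(Oc3ncnc4ccsc34)cc2)n1` gives 7800 nM

All three were tested in a functional assay on A549 cells (Homo sapiens) for inhibition, read by MTT assay, with a stated time of 72 h; on this read-out lower numbers stand for stronger inhibition and higher numbers for weaker inhibition. On these numbers compound 1 has the lowest value, with compound 3 within the scatter of it and compound 2 beyond it, as the step of a 2.5-fold higher number from compound 1 to compound 2 (0.40 log units; beyond the scatter) shows; that step changed only the bicyclic ring on the ether oxygen.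

Compound 4 `CN(c1ccc(Oc2ncnc3sccc23)cc1)c1nccc(N2CCCC2)n1` differs from compound 1 at the other end of the molecule: pyrrolidin-1-yl in place of 1,2,3,4-tetrahydroisoquinolin-2-yl on an aromatic carbon. For the measured compounds named here, no measured step touches this ring, so the expectation rests on weak evidence. Compound 3 carries a piperidine ring at that same place and differs from compound 1 in two further ways, and its value sits within the scatter of compound 1, which hints that a smaller saturated ring here need not cost much. The pyrrolidine is smaller still, and a modest loss or no change beyond the scatter seems the likelier outcome.

Compound 4 is therefore expected to show 9000 nM, within a range from 3000 nM to 30000 nM. This estimate means an expected step of a 1.4-fold higher number from compound 1 to compound 4 (0.15 log units; within the scatter).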

Compound 4, half-maximal inhibitory concentration: 15100 nM
Estimate against measurement, compound 4: 1.7-fold (0.22 log units) below; the range from low to high includes it.
By their numbers in this assay, from the lowest: compounds 1, 3, 4 and 2 (each within the scatter of the next, the first and the last beyond it).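

In this assay, for the compounds shown here, putting pyrrolidin-1-yl in place of 1,2,3,4-tetrahydroisoquinolin-2-yl on this aromatic carbon gives a 2.4-fold higher number from compound 1 to compound 4 (0.37 log units; beyond the scatter), the first reading of a change made at this place alone, and it shows that the group here does affect the number, though only modestly. The change leaves a smaller group at this place and removes the six-membered aromatic ring of carbon only, while both groups have the same count of hydrogen-bond donors and acceptors and neither carries a net charge. No measurement of any property of these groups accompanies the result, so nothing here accounts for the step.

On these data alone, with one replacement on the core of compound 1, it remains open whether the higher number follows the smaller group or the absence of the aromatic ring, and compound 3 cannot settle this as it differs in other places too. A morpholine ring or an open-chain dimethylamino group on the same aromatic carbon, with the rest of compound 1 unchanged, would help separate these two readings.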